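Solubility across the chain-substituted series and a ring replacement

This account rests on a few compounds, and the source may have more. Where it says the series, first, only, none or still open, it means among the compounds named here.

Measured in a physicochemical assay for solubility, with a stated time of 18 h, at pH 7.4; a higher number here means a more soluble compound, a lower number a less soluble compound:
- compound 1 `COc1ccc(F)cc1CNCCCNc1ccnc2cc(CCC(C)C)ccc12`: 4200 nM
- compound 2 `COc1ccc(F)cc1CNCCCNc1ccnc2cc(CCc3ccccc3)ccc12`: 4200 nM
- compound 3 `COc1ccc(F)cc1CNCCCNc1ccnc2cc(CC(C)C)ccc12`: 4200 nM

Compound 3 stands level with compounds 1 and 2 on these numbers. The steps among the three are flat: no change at the digits printed from compound 1 to compound 2 (within the scatter); no change at the digits printed from compound 1 to compound 3 (within the scatter); no change at the digits printed from compound 2 to compound 3 (within the scatter). Neither a phenyl placed two bonds along a saturated chain nor a shortening of the chain from isobutyl to isopropyl moved the read-out beyond the scatter.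

Compound 4 `COc1ccc(F)cc1CNCCCNc1ccnc2cc(-c3ccccc3)ccc12` is not yet measured. Relative to compound 3 the change is phenyl in place of isobutyl on an aromatic carbon. Here the isobutyl group leaves entirely and the phenyl enters directly on the ring carbon of the shared core, so none of the measured steps covers this exact exchange; the closest ones are the introduction of a phenyl in compound 2 and the removal of chain carbons in compound 3, both without change. On that basis no step beyond the scatter is expected, and the expected step is a 1.2-fold lower number from compound 3 to compound 4 (0.08 log units; within the scatter). Compound 4 is therefore estimated at 3500 nM, in the range 1200 nM to 8500 nM.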

Compound 4, solubility: 32000 nM
Compound 4: middle estimate off by 9.1-fold (0.96 log units), on the low side; the measured number lies above the stated range.
By their numbers in this assay, from the lowest: compounds 1, 2 and 3 (each within the scatter of the next); then compound 4.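

In this assay this aromatic carbon of the shared core proves sensitive to the group it carries: the number rises a 7.6-fold higher number from compound 3 to compound 4 (0.88 log units; beyond the scatter) and a 7.6-fold higher number from compound 2 to compound 4 (0.88 log units; beyond the scatter) and a 7.6-fold higher number from compound 1 to compound 4 (0.88 log units; beyond the scatter) when phenyl stands directly on the ring carbon. The flat steps among isobutyl, phenethyl and isopentyl therefore hold only among groups attached through a saturated chain carbon, and the phenyl at the end of the chain in compound 2 does not predict the directly attached phenyl of compound 4. Nothing measured here accounts for the rise.

As far as these compounds go, whether the higher number belongs to phenyl specifically or to direct attachment of a ring at this carbon remains open. Also open, from the compounds shown here alone, is how this position would respond to an amine, a carboxylic acid or a phenyl carrying either group.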